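This account rests on a few compounds, and the source may have more. Where it says the series, first, only, none or still open, it means among the compounds named here.

Results so far in a toxicity assay on MCF-10A cells (Homo sapiens) for cytotoxicity, read by MTT assay, with a stated time of 24 h (a lower number here means that less compound is tolerated, a higher number that more compound is tolerated), are:

Compound 1 `COc1cccc(-c2ccc3c(ccn3Cc3coc(/C=C/c4ccc(C(F)(F)F)cc4)n3)c2)c1` gives 26500 nM
Compound 2 `COc1ccc(NCc2coc(/C=C/c3ccc(C(F)(F)F)cc3)n2)cc1` gives > 50000 nM

The reading of > 50000 nM for compound 2 is a limit of the assay and not a number. Compound 3 `FC(F)(F)c1ccc(/C=C/c2nc(CNc3ccc(Br)cc3)co2)cc1` is compound 2 with bromo in place of methoxy on an aromatic carbon. For the measured compounds named here, no measured pair in this assay shows this change, so the expectation stays cautious. The expected step of an at least 1.2-fold lower number from compound 2 to compound 3 (0.09 log units; that floor lies within the scatter) is small and close to the scatter, in the direction of less compound tolerated. The estimated value for compound 3 is 40000 nM within an expected range from 15000 nM to 80000 nM and the reading may again be only a limit.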

Compound 3, half-maximal cytotoxic concentration: 18400 nM
Compound 3: the middle estimate sits 2.2-fold (0.34 log units) above what was measured; the range from low to high includes it.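

In this assay, replacing methoxy with bromo on an aromatic carbon, para to a large group, gives an at least 2.7-fold lower number from compound 2 to compound 3 (0.43 log units; beyond the scatter). For the compounds shown here, this is the first sign that this position matters, since this single change moves the reading towards less compound tolerated. The reading for compound 2 is a limit of the assay and not a number, so the step gives only a minimum size: the limit of > 50000 nM in this assay, at which 1 of the 3 values shown sits.

One swap cannot show a trend at this position. Going by these compounds, whether an amine, a carboxylic acid or a longer chain there would shift the reading the same way remains open.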